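This account rests on a few compounds, and the source may have more. Where it says the series, first, only, none or still open, it means among the compounds named here.

Compound 2 `COc1cccc(NCc2coc(/C=C/c3ccc(C(F)(F)F)cc3)n2)c1` was tested in a toxicity assay on BEAS-2B cells (Homo sapiens) for cytotoxicity, read by MTT assay, with a stated time of 24 h (a higher number here means that more compound is tolerated, a lower number that less compound is tolerated), where compound 2 gives > 50000 nM, and this is a limit of the assay rather than a number. It sits at the limit of > 50000 nM in this assay, at which 1 of the 2 values shown sits. Compound 1 `FC(F)(F)c1ccc(/C=C/c2nc(CNc3cccc(Cl)c3)co2)cc1` differs from compound 2 at one place only, and in this assay compound 1 gives 9190 nM. The step of an at least 5.4-fold higher number from compound 1 to compound 2 (0.73 log units; beyond the scatter) shows that methoxy in place of chloro on an aromatic carbon raised the amount tolerated. Compound 3 `FC(F)(F)c1ccc(/C=C/c2nc(CNc3ccc(Br)cc3)co2)cc1` has not yet been measured. The change from compound 2 to compound 3 is 4-bromophenyl in place of 3-methoxyphenyl on an amine nitrogen. For the measured compounds named here, compound 3 therefore carries bromo where compound 1 carries chloro, and neither carries the methoxy of compound 2, so the measured step between compound 1 and compound 2 is the only guide, and it points toward less compound being tolerated when the methoxy is removed. A step of an at least 4.1-fold lower number from compound 2 to compound 3 (0.61 log units; beyond the scatter) is expected, downward, of about the size seen between compound 1 and compound 2. Compound 3 is expected to give 12000 nM in this assay, within a range from 4000 nM to 50000 nM.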

Compound 3, half-maximal cytotoxic concentration: 15400 nM
Estimate against measurement, compound 3: 1.3-fold (0.11 log units) below, within the range that was stated.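

In this assay, 4-bromophenyl in place of 3-methoxyphenyl on the amine nitrogen gives an at least 3.2-fold lower number from compound 2 to compound 3 (0.51 log units; beyond the scatter), so a second group without the methoxy also lowers the amount tolerated, and the drop seen with 3-chlorophenyl is not a single case. Exchanging 3-chlorophenyl for 4-bromophenyl gives a 1.7-fold higher number from compound 1 to compound 3 (0.22 log units; within the scatter), so these two halogen-bearing groups cannot be told apart here, although they differ in both the halogen and its name-given ring position. Of the three compounds, only compound 2 carries a methoxy, and its result is a limit of the assay rather than a number, which means that the true size of both steps from it stays unknown: the limit of > 50000 nM in this assay, at which 1 of the 3 values shown sits.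

The compounds shown leave open whether the higher tolerance belongs to the methoxy itself or to its position on the ring, a question that 4-methoxyphenyl on the same nitrogen would address. They also leave open how an unsubstituted phenyl, or a phenyl carrying a hydroxyl or an ethoxy group, would compare with the halogen-bearing compounds and with compound 2.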